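Compound 1 to compound 3: a hetero atom in the ring

The source may report more compounds than this note shows. Statements on the series, on what has been measured and on what is new or still open speak of the compounds shown alone.

For the measured compounds named here, in an ADME assay on microsomes from liver (Homo sapiens) for metabolic stability, with a stated time of 10 min (a higher number here means that more of the compound is left, a lower number that less of the compound is left), compound 1 (`FC(F)(F)c1ccccc1-c1cc(Cl)c2[nH]c(C3=NOC4(CCCCC4)C3)nc2c1`) gives 92%, the higher of the two numbers so far, and compound 2 (`N#Cc1cc(-c2ccccc2C(F)(F)F)cc2nc(C3=NOC4(CCCCC4)C3)[nH]c12`) gives 68%. Compound 3 (`FC(F)(F)c1ccccc1-c1cc(Cl)c2[nH]c(C3=NOC4(CCOCC4)C3)nc2c1`) departs from compound 1 in one group: a group of 10 heavy atoms (7 carbon, 1 nitrogen, 2 oxygen; one five-membered non-aromatic ring with 2 hetero atoms, one six-membered non-aromatic ring with 1 hetero atom) in place of a group of 10 heavy atoms (8 carbon, 1 nitrogen, 1 oxygen; one five-membered non-aromatic ring with 2 hetero atoms, one six-membered non-aromatic ring of carbon only), on an aromatic carbon. A six-membered non-aromatic ring of carbon only gives way to a six-membered non-aromatic ring with 1 hetero atom. Going by the values given here, the sole measured step, a number 24 percentage points lower from compound 1 to compound 2 (beyond the scatter), is modest but beyond the scatter. It reflects cyano in place of chloro on an aromatic carbon, a different change in a different group, so it offers only weak guidance here. Among the compounds with values here, no measured step covers the present change. The expected step, a number 5 percentage points lower from compound 1 to compound 3 (within the scatter), is therefore small and not expected to exceed the scatter. For compound 3 the estimated value is 87%, with an expected range of 70% to 100%.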

Compound 3, percent of the compound remaining: 100%
Beside the measured number, compound 3's estimate is 13 percentage points below it, within the range that was stated.
By their numbers in this assay, from the lowest: compound 2; then compounds 1 and 3 (each within the scatter of the next).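

In this assay, replacing the six-membered non-aromatic ring of carbon only with a six-membered non-aromatic ring with 1 hetero atom gives a number 8 percentage points higher from compound 1 to compound 3 (within the scatter), so this step stays within the scatter. For the compounds shown here, it is the first reading at the place on an aromatic carbon, between two ring nitrogen atoms, and it contrasts with the cyano for chloro change, a number 24 percentage points lower from compound 1 to compound 2 (beyond the scatter), which lies beyond the scatter and sits in a different group. No available measurement bears on why the two rings read alike.

From the compounds shown here alone, whether an amine nitrogen in place of the ring oxygen, or a carboxylic acid on that ring, would also stay within the scatter of compound 1 remains open. Also open, going by these compounds, is whether the ring with 1 hetero atom would read the same alongside the cyano group of compound 2.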